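Methoxy to Nitro on a Pendant Phenyl Ring

The source may report more compounds than this note shows. Statements on the series, on what has been measured and on what is new or still open speak of the compounds shown alone.

The measured compounds:
Compound 1 `CC(C)Cc1ccc(C(C)c2n[nH]c(=S)n2N)cc1` — "not active" (no number reported)
Compound 2 `COc1ccc(C2=Nn3c(nnc3C(C)c3ccc(-c4ccccc4)c(F)c3)SC2)cc1` — 4200 nM
Compound 3 `COc1ccc2cc(C(C)c3n[nH]c(=S)n3N)ccc2c1` — 40000 nM

Three compounds have been examined in a functional assay on HepG2 cells (Homo sapiens) for inhibition, read by sulforhodamine B assay, with a stated time of 72 h; on this read-out higher numbers stand for weaker inhibition and lower numbers for stronger inhibition. Compound 1 is recorded as "not active" (no number reported) in this assay, and no number is reported for it. Of the two compounds with numbers, compound 2 gives 4200 nM, while compound 3 gives 40000 nM; the gap between them lies beyond the usual scatter, so compound 2 stands as the lower of the two numbers. The two compounds differ in more than one place, so their values can only be set side by side, not traced to a single change.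

Compound 4 `CC(c1ccc(-c2ccccc2)c(F)c1)c1nnc2n1N=C(c1ccc([N+](=O)[O-])cc1)CS2` has not yet been measured. It differs from compound 2 in one place: nitro in place of methoxy on an aromatic carbon. Within the data shown here, no pair of measured compounds isolates a change of this kind, so there is no step of known size to lean on. The expectation for compound 4 is therefore anchored on compound 2, with a step of a 1.2-fold higher number from compound 2 to compound 4 (0.08 log units; within the scatter) that is not expected to reach beyond the scatter in either direction. On this basis compound 4 is estimated at 5000 nM in this assay, within a range of 1500 nM to 16000 nM.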

Compound 4, half-maximal inhibitory concentration: 4300 nM
The estimate for compound 4 lay 1.2-fold (0.07 log units) above the measured number, within the range that was stated.
By their numbers in this assay, from the lowest: compounds 2 and 4 (each within the scatter of the next); then compound 3.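

In this assay, nitro in place of methoxy gives a 1.0-fold higher number from compound 2 to compound 4 (0.01 log units; within the scatter) and so provides the only step among these compounds that can be traced to a single place. The numbers of the pair cannot be told apart, which shows that on this six-membered aromatic ring of carbon only, para to a large group, 4-nitrophenyl and 4-methoxyphenyl read alike on the shared core, something the earlier side-by-side comparison could not show. No measurement is available to explain why the two groups read alike.

Still open, from the compounds shown here alone, is whether this position would read the same with an amine, a carboxylic acid or a longer chain such as butoxy, since a single step between two groups cannot show how far the result extends. Also open, going by these compounds, is whether the same exchange would read alike on a different core, such as that of compound 3, which carries a methoxy group of its own and stands at 40000 nM in this assay.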